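Tosylate series, chloro to methoxy on the aryl triazole

A few compounds are considered here, and "the series" means these few. Any claim that something is new, unique, unknown or untested is made for them only; others in the source may bear on it.

Compound 2 `Cc1ccc(S(=O)(=O)Oc2ccc3c(c2C)[C@H](Cn2cc(-c4ccc(Cl)cc4)nn2)[C@@]24CC(=O)[C@@](C)(CC[C@@H]32)C4)cc1` sits at the upper limit of a functional assay on HL-60 cells (Homo sapiens) for cytotoxicity, read by MTT assay, with a stated time of 4 days; a lower number here means a stronger inhibitor, a higher number a weaker inhibitor: in this assay compound 2 gives > 20000 nM, which is a limit of the assay and not a number. Its parent phenol, compound 1 `Cc1c(O)ccc2c1[C@H](Cn1cc(-c3ccc(Cl)cc3)nn1)[C@@]13CC(=O)[C@@](C)(CC[C@@H]21)C3`, is also at the limit; in this assay compound 1 gives > 20000 nM. The step from compound 1 to compound 2 is therefore a step that the two limits leave unreadable from compound 1 to compound 2, the (4-methylphenyl)sulfonyl entering in place of hydrogen on the phenolic oxygen without a readable effect. Compound 3 `C=C1C[C@]23C[C@@]1(O)CC[C@H]2c1ccc(OS(=O)(=O)c2ccc(C)cc2)c(C)c1[C@@H]3Cn1cc(-c2ccc(F)cc2)nn1`, with a fluorophenyl on the triazole and a different core, is likewise only a limit; in this assay compound 3 gives > 20000 nM. Taken together, (the limit of > 20000 nM in this assay, at which 3 of the 3 values shown sit), so no measured step in this set carries any size.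

Compound 4 `COc1ccc(-c2cn(C[C@H]3c4c(ccc(OS(=O)(=O)c5ccc(C)cc5)c4C)[C@@H]4CC[C@@]5(C)C[C@]43CC5=O)nn2)cc1` differs from compound 2 by methoxy in place of chloro on an aromatic carbon. Going by the values given here, no measured step touches this aryl substituent, and the only step that is measured is unreadable, so no movement beyond the scatter is expected from compound 2 to compound 4; the expected step is a step that the limit leaves unreadable from compound 2 to compound 4. Compound 4 is therefore estimated to remain at or beyond the limit, with an estimate in this assay of 30000 nM and a range from 10000 nM to 100000 nM, most likely reported again only as a limit.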

Compound 4, half-maximal inhibitory concentration: > 20000 nM
Compound 4: only a limit was reported (the forecaster's own chance of this, stated with the estimate: 80%); the middle value lies beyond the limit too.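

Compound 2 and compound 4 both stand only at a limit, so methoxy in place of chloro gives no readable step in this assay: the limit of > 20000 nM in this assay, at which 4 of the 4 values shown sit.

Still open is whether any change to the aryl group on the triazole, the phenolic oxygen or the core moves cytotoxicity in this assay, with no compound shown yet giving a number.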